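A few compounds are considered here, and "the series" means these few. Any claim that something is new, unique, unknown or untested is made for them only; others in the source may bear on it.

Three compounds built on one shared core have been examined in a functional assay on the whole organism for inhibition, with Rattus norvegicus as the target, read by paw edema, at a dose of 100 mg/kg by the oral route; a lower number here means less inhibition, a higher number more inhibition at the dose given (going by the name of the read-out). Compound 1 `CNC(=O)c1c(O)c2cccnc2n(-c2ccccc2)c1=O` gives 9.6%. Compound 2 `O=C(Nc1ccc([N+](=O)[O-])cc1)c1c(O)c2cccnc2n(-c2ccccc2)c1=O` gives -7.6%, and compound 3 `O=C(Nc1cccc(Cl)c1)c1c(O)c2cccnc2n(-c2ccccc2)c1=O` gives 7.6%. Compound 3 therefore stands second highest of the three numbers: its nearest neighbour is compound 1, and those two lie within the usual scatter of each other, while the furthest is compound 2, which sits lower by a margin beyond the scatter. Among the measured compounds shown here, every measured step so far changes only the group on the amide-type nitrogen: a number 17.2 percentage points lower from compound 1 to compound 2 (beyond the scatter), a number 2 percentage points lower from compound 1 to compound 3 (within the scatter), and a number 15.2 percentage points higher from compound 2 to compound 3 (beyond the scatter).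

Compound 4 `O=C(Nc1cnccn1)c1c(O)c2cccnc2n(-c2ccccc2)c1=O` differs from compound 3 in one place: pyrazin-2-yl in place of 3-chlorophenyl on an amide-type nitrogen. For the measured compounds named here, no measured compound carries a pyrazin-2-yl at that position, so the earlier steps give only a rough scale for the swap. Because a number 2 percentage points lower from compound 1 to compound 3 (within the scatter) and a number 15.2 percentage points higher from compound 2 to compound 3 (beyond the scatter) are both small, the change is expected to shift the number only modestly, with a number 2.6 percentage points lower from compound 3 to compound 4 (within the scatter). Compound 4 is thus estimated at 5%, with a likely range from -10% to 20%.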

Compound 4, a percentage reported as inhibition, in the whole organism at one dose (the size of the read-out at that dose, not a potency): 29.6%
For compound 4 the middle estimate is 24.6 percentage points below the measured one; the whole stated range lies below it.
By their numbers in this assay, from the lowest: compound 2; then compounds 3 and 1 (each within the scatter of the next); then compound 4.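

In this assay, the group on the amide-type nitrogen can now be seen to raise the number as well as lower it: the swap from methyl to pyrazin-2-yl gives a number 20 percentage points higher from compound 1 to compound 4 (beyond the scatter), whereas neither substituted phenyl group gave a rise beyond the scatter over methyl. Exchanging a carbon-only aromatic ring for one with hetero atoms gives a number 22 percentage points higher from compound 3 to compound 4 (beyond the scatter) and also a number 37.2 percentage points higher from compound 2 to compound 4 (beyond the scatter), so the kind of ring at this place matters to the read-out. Nothing available explains this rise.

Each of these swaps changes the ring and also removes a chlorine or a nitro group, so the two changes cannot yet be told apart; a plain phenyl or a pyridin-2-yl on this nitrogen would help to separate them. As far as these compounds go, it also remains open how a longer chain ending in an amine would behave here.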